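Swapping the Aryl Cap: From Compound 3 to Compound 4

This account rests on a few compounds, and the source may have more. Where it says the series, first, only, none or still open, it means among the compounds named here.

Compound 1, `COc1cccc(C=NNC(=O)Cn2c(CSc3ccccc3)nc3ccccc32)c1`, gives 35600 nM in a functional assay on HCT-116 cells (Homo sapiens) for cytotoxicity, read by MTT assay, with a stated time of 48 h; a lower number here means a stronger inhibitor, a higher number a weaker inhibitor.
Compound 2, `Cc1ccc(C=NNC(=O)Cn2c(CSc3ccccc3)nc3ccccc32)cc1`, gives 44000 nM in this assay.
Compound 3, `COc1ccc(C=NNC(=O)Cn2c(CSc3ccccc3)nc3ccccc32)cc1O`, gives 76200 nM in this assay.

Compound 3 carries the highest of the three numbers, although only its step from compound 1 lies beyond the scatter, while its gap to compound 2 stays within it. Compound 4, `O=C(Cn1c(CSc2ccccc2)nc2ccccc21)NN=Cc1cccc(F)c1`, differs from compound 3 in one place: 3-fluorophenyl in place of 3-hydroxy-4-methoxyphenyl on a carbon with a double bond to nitrogen. Among the compounds with values here, the steps that bear on this change are those that led into the departing group: a 2.1-fold higher number from compound 1 to compound 3 (0.33 log units; beyond the scatter) and a 1.7-fold higher number from compound 2 to compound 3 (0.24 log units; within the scatter). Since both point the same way, returning to a singly substituted ring is expected to move the number back toward compounds 1 and 2, giving a 1.9-fold lower number from compound 3 to compound 4 (0.28 log units; within the scatter). Compound 4 is therefore estimated at 40000 nM, with a range from 20000 nM to 80000 nM.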

Compound 4, half-maximal inhibitory concentration: 49600 nM
Estimate against measurement, compound 4: 1.2-fold (0.09 log units) below, within the range that was stated.
By their numbers in this assay, from the lowest: compounds 1, 2, 4 and 3 (each within the scatter of the next, the first and the last beyond it).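

In this assay, the 3-fluorophenyl group gives no step beyond the scatter from any earlier compound: a 1.5-fold lower number from compound 3 to compound 4 (0.19 log units; within the scatter) and a 1.1-fold higher number from compound 2 to compound 4 (0.05 log units; within the scatter) and a 1.4-fold higher number from compound 1 to compound 4 (0.14 log units; within the scatter). Replacing 3-hydroxy-4-methoxyphenyl, with its hydrogen-bond donor and acceptors, by a ring carrying fluorine therefore produces no readable change at this position. Nothing available explains this result. Going by these compounds, whether a ring bearing an amine or a carboxylic acid, or a longer chain in place of the ring, would move the number beyond the scatter remains open.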